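A Shorter Chain Beyond the Sulfonyl Sulfur

The source may hold more compounds than are shown below. What is called first, only, known or untested is meant among the compounds shown, and "the series" means these compounds.

For the measured compounds named here, in a functional assay, read by fluorescence and spectrophotometry, with a stated time of 1 h (a higher number here means that more compound is needed for the effect, a lower number that less compound is needed), compound 1 `CCCCCCCCCCCCS(=O)(=O)/C=C/c1ccc(O)c(O)c1` gives 8500 nM, the highest of the two numbers measured so far. Compound 2 `CCCCCCS(=O)(=O)/C=C/c1ccc(O)c(O)c1` gives 7300 nM in this assay, and the step of a 1.2-fold lower number from compound 1 to compound 2 (0.07 log units; within the scatter) stays within the scatter. Compound 3 `CCCCCCCCCS(=O)(=O)/C=C/c1ccc(O)c(O)c1` differs from compound 1 by hydrogen in place of propyl on a saturated chain carbon, nine bonds along the chain from a sulfonyl sulfur. Going by the values given here, the only measured step that bears on this change is the one from hexyl to hydrogen on the same chain, which stayed within the scatter, so the expected step is a 1.1-fold lower number from compound 1 to compound 3 (0.03 log units; within the scatter), nothing beyond the scatter. Compound 3 is therefore estimated at 7900 nM, with a range from 4000 nM to 16000 nM.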

Compound 3, half-maximal effective concentration: 7700 nM
For compound 3 the middle estimate is 1.0-fold (0.01 log units) above the measured one; low and high end bracket the measured number.
By their numbers in this assay, from the lowest: compounds 2, 3 and 1 (each within the scatter of the next).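

Taking propyl off at the place nine bonds along the chain from a sulfonyl sulfur gives a 1.1-fold lower number from compound 1 to compound 3 (0.04 log units; within the scatter) in this assay and separates nothing, and putting propyl in place of hydrogen six bonds along the chain gives a 1.1-fold higher number from compound 2 to compound 3 (0.02 log units; within the scatter) and separates nothing either. Compound 1, compound 2 and compound 3 therefore cannot be told apart here, and a second cut on the same chain reads like the first. No evidence bears on the reason for this.

Going by these compounds, whether a methyl chain, or an amine or a carboxylic acid at the chain end, would give a step beyond the scatter stays open.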